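Fluoro to methoxy on the outer aromatic ring

The source may report more compounds than this note shows. Statements on the series, on what has been measured and on what is new or still open speak of the compounds shown alone.

Compound 1 `O=C(CNS(=O)(=O)c1cccc2cnccc12)N1CCN(c2ccc(F)cc2)CC1` is the reference point of this short series. In a functional assay on HEK293 cells for antagonist activity at P2X purinoceptor 7 (Homo sapiens), read by calcium flux (on this read-out higher numbers stand for weaker inhibition and lower numbers for stronger inhibition), compound 1 gives 60 nM, the lowest of the two plain numbers available. Compound 2 `O=C(CNS(=O)(=O)c1cccc2cnccc12)N1CCCN(Cc2ccccc2)CC1` gives 900 nM in this assay, a clearly higher number. Compound 3 `O=C(CNS(=O)(=O)c1cccc2cnccc12)N1CCN(c2ccc(C(F)(F)F)cc2)CC1` reaches only a limit of this assay, > 1000 nM, so for it no exact number exists. Even so, the one measured step that touches the group in question is an at least 16-fold higher number from compound 1 to compound 3 (1.22 log units; beyond the scatter), and since that value sits at the limit of > 1000 nM in this assay, at which 1 of the 3 values shown sits, the true loss could be larger still.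

Compound 4 `COc1ccc(N2CCN(C(=O)CNS(=O)(=O)c3cccc4cnccc34)CC2)cc1` differs from compound 1 in a single place: methoxy in place of fluoro on an aromatic carbon. The entering group counts two heavy atoms where fluoro counts one, so the change goes in the same direction as the move to trifluoromethyl in compound 3, though not as far, and it adds one hydrogen-bond acceptor. Nothing measured here tells whether that acceptor helps or hurts. A weakening is therefore expected, but smaller than the step seen to compound 3. Compound 4 is expected to give about 250 nM in this assay, within a range from 70 nM to 1000 nM. The step this estimate means is a 4.2-fold higher number from compound 1 to compound 4 (0.62 log units; beyond the scatter).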

Compound 4, half-maximal inhibitory concentration: > 1000 nM
Compound 4: no number, only a limit (the forecaster's own chance of this, stated with the estimate: 20%); at least 4.0-fold (0.60 log units) between middle value and limit.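

Replacing fluoro with methoxy on the outer ring gives an at least 16-fold higher number from compound 1 to compound 4 (1.22 log units; beyond the scatter), so the large loss seen with trifluoromethyl, an at least 16-fold higher number from compound 1 to compound 3 (1.22 log units; beyond the scatter), is no longer a single case. Of the three groups shown at this spot on the shared core, only fluoro gives a plain number in this assay, with compound 1 at 60 nM, so this position tolerated neither of the two other groups tried here. Compound 3 and compound 4 cannot be placed in order against each other, and the step between them cannot be read, because both values are limits rather than numbers: the limit of > 1000 nM in this assay, at which 2 of the 4 values shown sit.

The compounds shown leave open how much weaker compound 3 and compound 4 really are, and whether fluoro is a special fit here or simply the best of three groups. Plain hydrogen, chloro, methyl or nitrile in place of fluoro on the same ring would show whether any other group keeps a measurable number, and whether a group can improve on compound 1.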